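Pyridin-2-yl in place of 4-fluorophenyl on compound 2

The source may hold more compounds than are shown below. What is called first, only, known or untested is meant among the compounds shown, and "the series" means these compounds.

In a functional assay on COR-L23 cells (Homo sapiens) for antiproliferative activity, read by CellTiter-Glo, with a stated time of 4 days (a lower number here means a stronger inhibitor, a higher number a weaker inhibitor), compound 1 `COCC(=O)N[C@@H](C)c1ccc(NC(=O)[C@H]2C[C@@H]2c2cccnc2)cc1` gives 111 nM, while compound 2 `C[C@H](NC(=O)c1ccc(F)cc1)c1ccc(NC(=O)[C@H]2C[C@@H]2c2cccnc2)cc1` gives 12 nM, the lower of the two numbers. Compound 3 `C[C@H](NC(=O)c1ccccn1)c1ccc(NC(=O)[C@H]2C[C@@H]2c2cccnc2)cc1` has pyridin-2-yl in place of 4-fluorophenyl on a carbonyl carbon of compound 2: pyridin-2-yl in place of 4-fluorophenyl on a carbonyl carbon. Among the compounds with values here, the only measured step at this place is a 9.3-fold lower number from compound 1 to compound 2 (0.97 log units; beyond the scatter), with 4-fluorophenyl in place of methoxymethyl. Within the data shown here, no measured pair shows how a ring nitrogen behaves here. Compound 3 still carries a six-membered aromatic ring at this place, so much of the difference seen at compound 2, with its 12 nM, is expected to persist. A small move toward a higher number in this assay is expected, estimated as a 2.5-fold higher number from compound 2 to compound 3 (0.40 log units; beyond the scatter). For compound 3 the estimated value is 30 nM, with an expected range of 10 nM to 90 nM.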

Compound 3, half-maximal inhibitory concentration: 46 nM
The estimate for compound 3 lay 1.5-fold (0.19 log units) below the measured number, and the stated range covers the measured number.
By their numbers in this assay, from the lowest: compound 2; then compound 3; then compound 1.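

In this assay, pyridin-2-yl in place of 4-fluorophenyl on a carbonyl carbon brings a 3.8-fold higher number from compound 2 to compound 3 (0.58 log units; beyond the scatter) and so shows that this position responds to which aromatic ring it carries, not only to the presence of one. Pyridin-2-yl in place of methoxymethyl still brings a 2.4-fold lower number from compound 1 to compound 3 (0.38 log units; beyond the scatter) and so keeps part of the step seen with 4-fluorophenyl, leaving both aromatic groups on the lower side of methoxymethyl. No measurement at hand gives a reason for the difference between the two rings.

This change removes the fluorine and brings in the ring nitrogen together, and the compounds shown do not separate the two. On these data alone, what a plain phenyl, a pyridin-3-yl or a piperidin-4-yl would give on this carbonyl carbon stays open.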